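This account rests on a few compounds, and the source may have more. Where it says the series, first, only, none or still open, it means among the compounds named here.

Measured compounds:
compound 1, `CCC(/C=C(\COC(C)=O)C(=O)c1ccccc1)CC`: 89000 nM
compound 2, `CC(=O)OC/C(=C\c1ccccc1)C(=O)c1ccccc1`: 16000 nM

For the measured compounds named here, in a functional assay on T47D cells (Homo sapiens) for inhibition, read by sulforhodamine B assay, with a stated time of 48 h (a lower number here means a stronger inhibitor of growth, a higher number a weaker inhibitor of growth), compound 2 gives the lower of the two numbers, with compound 1 as its only neighbour at a higher number; the single measured step is a 5.6-fold lower number from compound 1 to compound 2 (0.75 log units; beyond the scatter). Compound 3, `CC(=O)OC/C(=C\c1ccccc1[N+](=O)[O-])C(=O)c1ccccc1`, differs from compound 2 in one place: nitro in place of hydrogen on an aromatic carbon. Going by the values given here, the only measured step concerns a change of the group on the double-bonded chain carbon, not a substituent on the aromatic ring, so no measured step bears directly on this change and no direction can be read from the series. With nothing to lean on, the expected step in this assay from compound 2 to compound 3 is small, most likely not beyond the scatter, as a 1.1-fold lower number from compound 2 to compound 3 (0.06 log units; within the scatter). Compound 3 is therefore estimated at 14000 nM, with a range from 5000 nM to 40000 nM.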

Compound 3, concentration for 50% growth inhibition: 21000 nM
Compound 3: the middle estimate sits 1.5-fold (0.18 log units) below what was measured; the range from low to high includes it.
By their numbers in this assay, from the lowest: compounds 2 and 3 (each within the scatter of the next); then compound 1.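

In this assay, nitro in place of hydrogen on an aromatic carbon, ortho to a large group, gives a 1.3-fold higher number from compound 2 to compound 3 (0.12 log units; within the scatter), so compound 2 and compound 3 cannot be told apart in this read-out. For the compounds shown here, the earlier step changed only the group on the double-bonded chain carbon; this is the first reading from the aromatic ring itself, and at this position the added nitro leaves the number within the scatter. Nothing measured here accounts for this result.

As far as these compounds go, whether an amine or a carboxylic acid on the same aromatic carbon would also leave the number within the scatter remains open. So does whether nitro would read the same on another carbon of this ring or on the phenyl of the ketone.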